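A Benzyl Group Enters the Thiourea Series

The source may report more compounds than this note shows. Statements on the series, on what has been measured and on what is new or still open speak of the compounds shown alone.

Of the compounds shown here, three have so far been measured in an ADME assay on Ava5 cells (Homo sapiens) for cytotoxicity; on this read-out higher numbers stand for lower toxicity in this test and lower numbers for higher toxicity in this test. Compound 1, `NC(=S)Nc1cccc(OCCCc2ccccc2)c1`, gives only a limit in this assay, > 50000 nM. Compound 2, `NC(=S)Nc1ccccc1OCCCCCc1ccccc1`, gives a number in this assay, 31000 nM. Compound 3, `CNC(=S)Nc1cccc(OCCCCCc2ccccc2)c1`, also reaches only a limit in this assay, > 50000 nM. Within the data shown here, compound 3 therefore stands at the limit of > 50000 nM in this assay, at which 2 of the 3 values shown sit, and because no pair of measured compounds differs in just one place, no measured step shows how any single change moves the read-out.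

Compound 4, `S=C(NCc1ccccc1)Nc1cccc(OCCCCCc2ccccc2)c1`, has not been measured yet. It differs from compound 3 in a single place: phenyl in place of hydrogen on a saturated chain carbon bound to an amide-type nitrogen. Among the measured compounds shown here, no measured compound shows what this change does to cytotoxicity, so the expectation rests on where compound 3 stands, which is only a limit, > 50000 nM. A modest move toward higher toxicity is expected, one that may well stay within the scatter, and a fair chance remains that the assay again reports only a limit. For compound 4 the estimated value is 35000 nM, with an expected range from 12000 nM to 60000 nM. The step this estimate implies is expected to be an at least 1.4-fold lower number from compound 3 to compound 4 (0.15 log units; that floor lies within the scatter).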

Compound 4, half-maximal cytotoxic concentration: 32000 nM
Beside the measured number, compound 4's estimate is 1.1-fold (0.04 log units) above it; low and high end bracket the measured number.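

Among these compounds, compound 3 and compound 4 form the first pair that differs in one place only, so they give the first measured step. In this assay, putting phenyl in place of hydrogen on a saturated chain carbon bound to an amide-type nitrogen, which turns methylamino into benzylamino, gives an at least 1.5-fold lower number from compound 3 to compound 4 (0.19 log units; that floor lies within the scatter). Only a floor can be stated for this step, and that floor lies within the usual scatter, because the starting point is a limit rather than a number: the limit of > 50000 nM in this assay, at which 2 of the 4 values shown sit.

So this pair shows that the read-out comes off the limit with phenyl at this place, but it does not fix how large the true shift is. From the compounds shown here alone, whether the aromatic ring matters, or any larger group at this place would do the same, stays open, and a straight propyl or butyl chain or a cyclohexyl ring there would help to separate the two. It is also unknown how the read-out would respond to an amine or a carboxylic acid on the new phenyl ring, or to a longer chain between that ring and the nitrogen.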